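The compounds below may be only part of what the source reports. "The series", "measured", "known", "first", "only" and "open" are said of these compounds alone.

Compound 1: `CS(=O)(=O)Nc1cccc2c1CCC2c1ncc[nH]1` — 70 nM
Compound 2: `Cc1c(OCC2=NCCN2)ccc(Cl)c1NS(C)(=O)=O` — 25 nM

Of the compounds shown here, two have been measured in a functional assay on CHO cells for agonist activity at Alpha-1A adrenergic receptor (Homo sapiens), read by FLIPR and calcium flux; a higher number here means that more compound is needed for the effect, a lower number that less compound is needed. Compound 1 gives 70 nM, the higher of the two numbers, while compound 2 gives 25 nM, a gap that lies beyond the usual scatter. The two share no single point of difference, so their values only set the range seen so far.

Compound 3, `Cn1cc(-c2cccc3c2CCC3c2ncc[nH]2)cn1`, is the untested compound that this piece follows. It differs from compound 1 by one change: 1-methyl-1H-pyrazol-4-yl in place of methanesulfonamido on an aromatic carbon. The group that leaves carries a hydrogen-bond donor; the ring that enters carries none. Among the measured compounds shown here, no measured pair shows such a swap, so its effect is not known from the data.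

The expected step is a moderate rise in the number, though a step within the scatter in either direction would not surprise: a 2.1-fold higher number from compound 1 to compound 3 (0.33 log units; beyond the scatter). Compound 3 is therefore estimated at 150 nM, with a range from 40 nM to 600 nM.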

Compound 3, half-maximal effective concentration: > 2900 nM
Compound 3: only a limit was reported; the forecaster's own chance of this, stated with the estimate: 10%; middle value at least 19-fold (1.28 log units) from the limit.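

In this assay, putting 1-methyl-1H-pyrazol-4-yl in place of methanesulfonamido on this aromatic carbon gives an at least 41-fold higher number from compound 1 to compound 3 (1.61 log units; beyond the scatter). This is the only single change shown on the core of compound 1, and it shows that the group at this position can change the number by far more than the usual scatter, even though the two groups differ little in heavy-atom count. Compound 3 gives > 2900 nM, which is a limit of the assay and not a number: the limit of > 2900 nM in this assay, at which 1 of the 3 values shown sits.

This one swap removes the hydrogen-bond donor and adds a ring at the same time, so it cannot show which of these differences matters. As far as these compounds go, it also remains open whether a simple amine or an acetamido group on this carbon would keep the number close to that of compound 1.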